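A few compounds are considered here, and "the series" means these few. Any claim that something is new, unique, unknown or untested is made for them only; others in the source may bear on it.

Measured compounds:
compound 1 `Cc1ccnc(/C(N)=N/NC(=S)N2CCSCC2)c1`: 6900 nM
compound 2 `N/C(=N\NC(=S)N1CCSCC1)c1ccccn1`: 8800 nM
compound 3 `Cc1cccc(/C(N)=N/NC(=S)N2CCCC2)n1`: 61800 nM

These three share one core and were tested in a functional assay on MCF7 cells (Homo sapiens) for cytotoxicity, read by MTT assay, with a stated time of 72 h; on this read-out higher numbers stand for weaker inhibition and lower numbers for stronger inhibition. Among them compound 1 gives the lowest number, with compound 2 close by and compound 3 far beyond the scatter from it. Among the measured compounds shown here, the only step that changes a single place runs from compound 1 to compound 2, and it is a 1.3-fold higher number from compound 1 to compound 2 (0.11 log units; within the scatter).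

Compound 4 `Cc1ccnc(/C(N)=N/NC(=S)N2CCCCC2)c1` is not yet measured. It differs from compound 1 in that (piperidin-1-yl in place of thiomorpholin-4-yl on a thiocarbonyl carbon). For the measured compounds named here, no measured step touches this kind of exchange on the thiocarbonyl carbon, because compound 3, which also carries a smaller ring without sulfur there, differs from compound 1 in a second place as well, so its higher number cannot be assigned to the ring alone. The expectation for compound 4 in this assay is therefore mostly unguided, leaning toward a somewhat higher number, and the estimated step of a 1.7-fold higher number from compound 1 to compound 4 (0.24 log units; within the scatter) stays modest. Compound 4 is expected to give about 12000 nM, within a range from 4000 nM to 40000 nM.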

Compound 4, half-maximal inhibitory concentration: 18800 nM
Compound 4: middle estimate off by 1.6-fold (0.19 log units), on the low side, within the range that was stated.
By their numbers in this assay, from the lowest: compounds 1 and 2 (each within the scatter of the next); then compound 4; then compound 3.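

In this assay, placing piperidin-1-yl instead of thiomorpholin-4-yl on the thiocarbonyl carbon gives a 2.7-fold higher number from compound 1 to compound 4 (0.44 log units; beyond the scatter). Among the compounds shown here, this is the first single-place step at this position, and it shows that the number responds to the ring there, modestly but beyond the scatter. The two rings are both six-membered and have the same count of heavy atoms, so the exchange amounts to a ring carbon standing where the ring sulfur stood, and nothing available explains why the number moves.

The compounds shown leave open whether sulfur itself matters or whether another ring atom would serve as well, as the oxygen of morpholin-4-yl or the second nitrogen of piperazin-1-yl might. They also leave open how an open-chain group such as dimethylamino would behave on the same carbon.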